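This account rests on a few compounds, and the source may have more. Where it says the series, first, only, none or still open, it means among the compounds named here.

Working notes on the series in an in vitro functional assay on 1321-N1 cells for agonist activity at Free fatty acid receptor 1 (Homo sapiens), read by fluorescence, spectrophotometry and calcium flux; on this read-out lower numbers stand for smaller maximal responses and higher numbers for larger maximal responses. Among the compounds with values here, compound 3 `O=C(O)CCc1ccc(C#Cc2ccnc(Cl)c2)cc1` gives 94%, the lowest of the three numbers so far, although its distance to each of the other two lies within the scatter. Compound 1 `O=C(O)CCc1ccc(C#Cc2ccnc(Cl)c2Cc2ccccc2)cc1` gives 101%; the step of a number 7 percentage points lower from compound 1 to compound 3 (within the scatter) is hydrogen in place of benzyl on an aromatic carbon. Compound 2 `O=C(O)CCc1ccc(C#Cc2cccnc2)cc1` gives 96%, within the scatter of compound 3. Compound 4 `Cc1cc(C#Cc2ccc(CCC(=O)O)cc2)ccn1` differs from compound 3 by methyl in place of chloro on an aromatic carbon. Within the data shown here, no measured step exchanges chloro for methyl, so none bears directly on this change; the one step available was within the scatter, and all three measured compounds reach a comparable maximal response in this assay. Compound 4 is therefore expected to give about 95% (range 84% to 106%). The expected step is a number 1 percentage points higher from compound 3 to compound 4 (within the scatter), none beyond the scatter.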

Compound 4, largest response reached (reported as efficacy), in percent of the reference or control that the assay uses: 102%
Compound 4: the middle estimate sits 7 percentage points below what was measured, within the range that was stated.
By their numbers in this assay, from the lowest: compounds 3, 2, 1 and 4 (each within the scatter of the next).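

Methyl in place of chloro next to the ring nitrogen gives a number 8 percentage points higher from compound 3 to compound 4 (within the scatter) in this assay. This position therefore carries either group with a comparable maximal response, so the chloro group of compound 3 is not needed for the response at this level. Within the data shown here, no evidence on the compounds bears on this result.

Going by these compounds, whether an amine, a methoxy group or a longer chain at this position would keep a comparable maximal response stays open. So does whether compound 4 would hold its response with benzyl added as in compound 1.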